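A few compounds are considered here, and "the series" means these few. Any claim that something is new, unique, unknown or untested is made for them only; others in the source may bear on it.

Measured compounds in a functional assay on B16 cells (Mus musculus) for cytotoxicity, read by MTT assay, with a stated time of 48 h; a lower number here means a stronger inhibitor, a higher number a weaker inhibitor:
- compound 1, `COc1cccc(Cn2cc(-c3ccc4ccccc4c3)nn2)c1`: > 100000 nM
- compound 2, `CCOC(=O)Cn1cc(-c2ccc3ccccc3c2)nn1`: > 100000 nM
- compound 3, `CC1(C)OC[C@H](Cn2cc(-c3ccc4ccccc4c3)nn2)O1`: 12000 nM

The values of compound 1 and compound 2 are limits of this assay and not numbers. Among the measured compounds shown here, compound 3 is the only compound with a number; it is therefore the reference point for everything that follows. Compound 4, `c1ccc(Cn2cc(-c3ccc4ccccc4c3)nn2)cc1`, has not yet been measured in this assay. The change from compound 3 to compound 4 is phenyl in place of 2,2-dimethyl-1,3-dioxolan-4-yl on a saturated chain carbon bound to an aromatic nitrogen. For the measured compounds named here, two measured steps bear on it: an at least 8.3-fold lower number from compound 1 to compound 3 (0.92 log units; beyond the scatter) and an at least 8.3-fold lower number from compound 2 to compound 3 (0.92 log units; beyond the scatter). Both steps replaced a group on that carbon with the dioxolane and gave a number where before only a limit was seen, and the limit of > 100000 nM in this assay, at which 2 of the 3 values shown sit, marks how far the limit lies from compound 3. Compound 4 reverses that kind of change, and phenyl resembles the 3-methoxyphenyl of compound 1 more than the dioxolane of compound 3. Compound 4 is therefore expected to show a step of an 8.3-fold higher number from compound 3 to compound 4 (0.92 log units; beyond the scatter) in this assay, most likely back to the limit. The estimate for compound 4 is 100000 nM, with a range from 20000 nM to 300000 nM.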

Compound 4, half-maximal inhibitory concentration: 3890 nM
Compound 4: the middle estimate sits 26-fold (1.41 log units) above what was measured; measured number below the stated range.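

In this assay, the dioxolane turns out not to be needed for a number at this saturated chain carbon, since phenyl in its place gives a 3.1-fold lower number from compound 3 to compound 4 (0.49 log units; beyond the scatter), and phenyl in place of ethoxycarbonyl gives an at least 25-fold lower number from compound 2 to compound 4 (1.41 log units; beyond the scatter). The sharpest contrast comes from a single small change on the aromatic ring, hydrogen in place of methoxy on an aromatic carbon, which gives an at least 25-fold lower number from compound 1 to compound 4 (1.41 log units; beyond the scatter), so an aromatic ring on this carbon can go with either a number or a limit. Compound 1 and compound 2 remain limits and not numbers, so the two steps from them are bounds only: the limit of > 100000 nM in this assay, at which 2 of the 4 values shown sit.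

The compounds shown leave open whether a fluorine or a hydroxyl on that aromatic carbon would behave like hydrogen or like methoxy. They also leave open whether an amine or a carboxylic acid in place of phenyl would still give a number.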